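The source may hold more compounds than are shown below. What is called first, only, known or untested is meant among the compounds shown, and "the series" means these compounds.

Compound 2 `CCCCOC(=O)Nc1cccc2c1CN(C)CC2c1ccccc1` gives 12 mg/kg in a functional assay on the whole organism for inhibition of sodium-dependent dopamine transporter (Mus musculus); a lower number here means that less compound is needed, a higher number that more compound is needed for the effect.
Compound 1 `CCCCNC(=O)Nc1cccc2c1CN(C)CC2c1ccccc1` gives 69 mg/kg in this assay.

Compound 2 holds the lower of the two numbers, the gap being a 5.8-fold lower number from compound 1 to compound 2 (0.76 log units; beyond the scatter). Compound 3 `CCCCNCC(=O)Nc1cccc2c1CN(C)CC2c1ccccc1` is not yet measured; it differs from compound 2 by (butylamino)methyl in place of butoxy on a carbonyl carbon. For the measured compounds named here, only one measured step touches the same spot, a 5.8-fold lower number from compound 1 to compound 2 (0.76 log units; beyond the scatter), which moved the number modestly when butoxy replaced butylamino; no measured pair shows the present exchange itself. Since part of the butylamino motif now returns, a modest rise of the number is expected, a 2.9-fold higher number from compound 2 to compound 3 (0.46 log units; beyond the scatter). Compound 3 is therefore estimated at 35 mg/kg, in a range from 10 mg/kg to 130 mg/kg.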

Compound 3, dose for half-maximal effect: 25 mg/kg
Compound 3: middle estimate off by 1.4-fold (0.15 log units), on the high side; measured number inside the range.
By their numbers in this assay, from the lowest: compound 2; then compound 3; then compound 1.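

In this assay, (butylamino)methyl on this carbonyl carbon gives a number closer to that of butoxy than butylamino did, though butoxy still keeps the lowest number (a 2.1-fold higher number from compound 2 to compound 3 (0.32 log units; beyond the scatter)). The butylamino part is therefore not equally unfavourable in every placement: as (butylamino)methyl in place of butylamino, it lowers the number (a 2.8-fold lower number from compound 1 to compound 3 (0.44 log units; beyond the scatter)). No measurement here explains either shift. Still open, as far as these compounds go, is how a longer chain or a carboxylic acid on this carbonyl carbon would compare with butoxy.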